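Adding a Methyl to the Ring Nitrogen of Compound 2

The source may report more compounds than this note shows. Statements on the series, on what has been measured and on what is new or still open speak of the compounds shown alone.

Of the compounds shown here, two have been measured in an in vitro functional assay on SH-EP1 cells for agonist activity at Neuronal acetylcholine receptor; alpha4/beta2 (Homo sapiens), read by FLIPR and calcium flux; a higher number here means a larger maximal response, a lower number a smaller maximal response. Compound 1 `COc1cncc(C2=CC3CC(C2)CN(C)C3)c1` gives 15% in this assay, while compound 2 `CC(C)Oc1cncc(C2=CC3CNCC(C2)C3)c1` reaches 54%, the higher of the two numbers and well beyond the scatter. Compound 3 `CC(C)Oc1cncc(C2=CC3CC(C2)CN(C)C3)c1` is compound 2 with one change: methyl in place of hydrogen on an amine nitrogen in a ring. Going by the values given here, no measured pair shows this step alone, so its size is open. Compound 3 is expected to sit somewhat below compound 2, with a step of a number 19 percentage points lower from compound 2 to compound 3 (beyond the scatter) that may be modest. Compound 3 is therefore estimated at 35%, with a range from 15% to 60%.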

Compound 3, largest response reached (reported as percent of maximum), in percent of the reference or control that the assay uses: 3.3%
The estimate for compound 3 lay 31.7 percentage points above the measured number; measured number below the stated range.
By their numbers in this assay, from the lowest: compound 3; then compound 1; then compound 2.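

Methyl in place of hydrogen on the amine nitrogen in a ring proves a large change in this assay, with a number 50.7 percentage points lower from compound 2 to compound 3 (beyond the scatter), so a single added carbon at this position can strongly lower the maximal response. With that methyl in place, isopropyl in place of methyl on the oxygen on the aromatic ring gives a modest step, a number 11.7 percentage points lower from compound 1 to compound 3 (beyond the scatter). Nothing shown here explains either step.

From the compounds shown here alone, whether an ethyl or a cyclopropyl on that nitrogen would lower the response further remains open. So does whether the oxygen's isopropyl matters equally when the nitrogen carries hydrogen.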